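A few compounds are considered here, and "the series" means these few. Any claim that something is new, unique, unknown or untested is made for them only; others in the source may bear on it.

Compound 1 `C/C(=N\NC(=O)/C(C#N)=C/c1ccccc1)c1c(O)c2ccc(O)cc2oc1=O` carries a cinnamoyl hydrazone bearing a nitrile on a shared coumarin-like core; its structure stands beside it. In a functional assay on NRK-49F cells (Rattus norvegicus) for cytotoxicity, read by MTT assay, with a stated time of 24 h (on this read-out higher numbers stand for weaker inhibition and lower numbers for stronger inhibition), compound 1 gives 55500 nM. Among the three measured compounds, compound 1 sits at the highest number, yet its steps to the others are within the scatter: compound 2 `C/C(=N\NC(=O)/C(C#N)=C/c1ccc(Br)cc1)c1c(O)c2ccc(O)cc2oc1=O` gives 49600 nM, a change of a 1.1-fold lower number from compound 1 to compound 2 (0.05 log units; within the scatter) through bromo in place of hydrogen on an aromatic carbon, and compound 3 `C/C(=N\NC(=O)/C(C#N)=C/c1ccc([N+](=O)[O-])cc1)c1c(O)c2ccc(O)cc2oc1=O` gives 43200 nM, a change of a 1.3-fold lower number from compound 1 to compound 3 (0.11 log units; within the scatter) through nitro in place of hydrogen on an aromatic carbon. Between these two, a 1.1-fold lower number from compound 2 to compound 3 (0.06 log units; within the scatter).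

Compound 4 `C/C(=N\NC(=O)/C(C#N)=C/c1cccc(Br)c1)c1c(O)c2ccc(O)cc2oc1=O` has not yet been measured. It differs from compound 1 in one place: bromo in place of hydrogen on an aromatic carbon, the bromine now entering meta to a large group. Going by the values given here, the only step that bears on it is the bromo entry from compound 1 to compound 2, which was a 1.1-fold lower number from compound 1 to compound 2 (0.05 log units; within the scatter). No step beyond the scatter is therefore expected; the estimated change is a 1.1-fold lower number from compound 1 to compound 4 (0.05 log units; within the scatter). Compound 4 is expected to give about 50000 nM, between 25000 nM and 100000 nM.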

Compound 4, half-maximal inhibitory concentration: 59400 nM
Compound 4: the middle estimate sits 1.2-fold (0.07 log units) below what was measured; the range from low to high includes it.
By their numbers in this assay, from the lowest: compounds 3, 2, 1 and 4 (each within the scatter of the next).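

Placing the bromine meta to a large group gives a 1.1-fold higher number from compound 1 to compound 4 (0.03 log units; within the scatter) in this assay, and 3-bromophenyl in place of 4-bromophenyl gives a 1.2-fold higher number from compound 2 to compound 4 (0.08 log units; within the scatter), so neither adding the bromine at this position nor shifting it around the ring separates these compounds. The comparison with the nitro compound, 3-bromophenyl in place of 4-nitrophenyl, gives a 1.4-fold higher number from compound 3 to compound 4 (0.14 log units; within the scatter), which means that all four compounds now lie within the scatter of one another. Nothing available here offers an explanation for this result.

The compounds shown leave open whether an amine or a carboxylic acid on this ring, or a longer chain in place of the ring, would move the number beyond the scatter. They also leave open whether a change on the shared core would do so.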